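Ring substitution on a shared core: fluorine leaves, methyl enters

The source may report more compounds than this note shows. Statements on the series, on what has been measured and on what is new or still open speak of the compounds shown alone.

Measured so far:
compound 1 `Cn1c(-c2ccc(F)cc2)nc2c(NC3CCCC3)ncnc21`: 6.2 nM
compound 2 `Cn1c(-c2ccccc2)nc2c(NC3CCCCC3)ncnc21`: 5.7 nM

Of the compounds shown here, two have been measured. In an assay on CHO cells for displacement of a labelled ligand from adenosine receptor A1 (Homo sapiens), read by scintillation counting, with a stated time of 3 h (a higher number here means a weaker inhibitor, a lower number a stronger inhibitor), compound 1 gives 6.2 nM, and in this assay compound 2 gives 5.7 nM. Going by the values given here, of these two numbers, the one for compound 1 is the higher, but the two lie within the scatter of each other, so nothing can be said about which compound is the stronger inhibitor.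

The next compound, compound 3 `Cc1ccccc1-c1nc2c(NC3CCCC3)ncnc2n1C`, has not yet been measured in this assay. It is made from compound 1 by a single change: 2-methylphenyl in place of 4-fluorophenyl on an aromatic carbon. The group that leaves and the group that enters are alike in size and in what they carry, differing only in which kind of atom sits on the ring and where.

Among the compounds with values here, no pair among the measured compounds shows what such a change does, so the expected step is small and may not rise beyond the scatter. The expected step is a 1.6-fold higher number from compound 1 to compound 3 (0.21 log units; within the scatter), leaning slightly toward a weaker inhibitor. Compound 3 is estimated at 10 nM, with a likely range from 3 nM to 35 nM.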

Compound 3, inhibition constant: 55 nM
Beside the measured number, compound 3's estimate is 5.5-fold (0.74 log units) below it; the whole stated range lies below it.
By their numbers in this assay, from the lowest: compounds 2 and 1 (each within the scatter of the next); then compound 3.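

In this assay the exchange of 4-fluorophenyl for 2-methylphenyl, on an aromatic carbon of a five-membered aromatic ring with 2 nitrogen, gives an 8.9-fold higher number from compound 1 to compound 3 (0.95 log units; beyond the scatter) and so moves beyond the scatter toward a weaker inhibitor. Going by these compounds alone, this is the first sign that this position is sensitive to the decoration of the aromatic ring it carries, since both the leaving and the entering group are built on a six-membered aromatic ring of carbon only and differ just in what sits on that ring and where. Nothing available here gives a measured reason for the loss.

The single step changes two things at once, the kind of group on the ring and its place on the ring, so the compounds shown cannot say which of the two accounts for the weaker binding. A compound carrying 4-methylphenyl or 2-fluorophenyl on the shared core would pull these two apart, and 2-chlorophenyl or 2-methoxyphenyl would show whether other groups in the place of that methyl behave the same way.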